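Taking the methoxy group off compound 3

The compounds below may be only part of what the source reports. "The series", "measured", "known", "first", "only" and "open" are said of these compounds alone.

In a functional assay on A549 cells (Homo sapiens) for cytotoxicity, read by WST assay, with a stated time of 24 h (a higher number here means a weaker inhibitor, a lower number a stronger inhibitor), compound 1 `COc1ccc2[nH]cc(/C=C(\C#N)C(=O)c3c[nH]c4ccccc34)c2c1` gives 6600 nM. Compound 2 `N#C/C(=C\c1c[nH]c2cc(F)ccc12)C(=O)c1c[nH]c2ccccc12`, which carries a fluoro group on the shared core, gives 17000 nM. Compound 3 `COc1ccc2c(/C=C(\C#N)C(=O)c3c[nH]c4ccccc34)c[nH]c2c1` gives 9600 nM. That is the second highest of the three numbers, yet it lies within the usual scatter of both others, so its place in this order is not firm.

Compound 4 `N#C/C(=C\c1c[nH]c2ccccc12)C(=O)c1c[nH]c2ccccc12` follows from compound 3 by a single change: hydrogen in place of methoxy on an aromatic carbon, (hydrogen in place of methoxy on an aromatic carbon). Going by the values given here, one measured step touches the same carbon. Methoxy in place of fluoro there gives a 1.8-fold lower number from compound 2 to compound 3 (0.25 log units; within the scatter), a small step that does not stand out from the scatter. Among the compounds with values here, every measured compound carries a methoxy or fluoro group, while compound 4 carries neither, so the data hold no direct example of this removal and the expectation stays loose. Within the data shown here, with only that small step from compound 2 to compound 3 as a guide, no shift beyond the scatter is expected in this assay, and the estimated change is a 1.1-fold higher number from compound 3 to compound 4 (0.06 log units; within the scatter). Compound 4 is expected at about 11000 nM, with an estimated range of 5000 nM to 25000 nM.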

Compound 4, half-maximal inhibitory concentration: 16100 nM
Compound 4: middle estimate off by 1.5-fold (0.17 log units), on the low side; low and high end bracket the measured number.
By their numbers in this assay, from the lowest: compounds 1, 3, 4 and 2 (each within the scatter of the next, the first and the last beyond it).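

In this assay taking the methoxy group off this carbon gives a 1.7-fold higher number from compound 3 to compound 4 (0.22 log units; within the scatter) and putting hydrogen in place of the fluoro group gives a 1.1-fold lower number from compound 2 to compound 4 (0.02 log units; within the scatter) here, so with hydrogen now measured at this carbon, neither group shifts the number beyond the scatter. Going by these compounds alone, the only step beyond the scatter, and a modest one, is a 2.4-fold higher number from compound 1 to compound 4 (0.39 log units; beyond the scatter) when the methoxy group leaves a different carbon of the shared core, which hints that a methoxy group may matter more there, although compound 1 and compound 3 lie within the scatter of each other and this rests on a single step. Nothing measured on these compounds accounts for these small differences.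

All the compounds shown carry only hydrogen, fluoro or methoxy on the shared core, so it stays open whether an amine, a carboxylic acid or a longer chain such as butoxy on this carbon would move the number beyond the scatter. From the compounds shown here alone, it also stays open whether the flat picture at this carbon would hold in another cell line.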